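Trifluoromethyl on the Anilino Ring of a Selenourea Coumarin

This account rests on a few compounds, and the source may have more. Where it says the series, first, only, none or still open, it means among the compounds named here.

Measured compounds:
compound 1, `CCCOC(=[Se])Nc1ccc2c(C)cc(=O)oc2c1`: 23000 nM
compound 2, `Cc1cc(=O)oc2cc(NC(=[Se])Nc3ccccc3)ccc12`: 24000 nM

In a functional assay on HeLa cells (Homo sapiens) for inhibition, read by sulforhodamine B assay, with a stated time of 48 h (on this read-out higher numbers stand for weaker inhibition of growth and lower numbers for stronger inhibition of growth), compound 1 gives 23000 nM and compound 2 gives 24000 nM. Going by the values given here, the one step measured so far, anilino in place of propoxy on a saturated chain carbon bound to a nitrogen on an aromatic ring, is a 1.0-fold higher number from compound 1 to compound 2 (0.02 log units; within the scatter), so the two numbers sit alongside each other and neither can be set above the other.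

Compound 3, `Cc1cc(=O)oc2cc(NC(=[Se])Nc3ccc(C(F)(F)F)cc3)ccc12`, carries the change trifluoromethyl in place of hydrogen on an aromatic carbon on the anilino ring of compound 2. Among the compounds with values here, no measured step touches that ring: the only step seen alters the group on the other side of the selenourea, and it was within the scatter. There is thus nothing in the data that points to a move in either direction, and the account expects no step beyond the scatter in this assay, the expected step being a 1.2-fold lower number from compound 2 to compound 3 (0.08 log units; within the scatter).

For compound 3 the estimate in this assay is 20000 nM, expected to fall between 7000 nM and 60000 nM.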

Compound 3, concentration for 50% growth inhibition: 21000 nM
Compound 3: the middle estimate sits 1.1-fold (0.02 log units) below what was measured; the measured number falls inside the stated range.
By their numbers in this assay, from the lowest: compounds 3, 1 and 2 (each within the scatter of the next).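

In this assay the step is a 1.1-fold lower number from compound 2 to compound 3 (0.06 log units; within the scatter) and so this change, the only one shown on the anilino ring, does not set the two compounds apart. Going by these compounds alone, at this aromatic carbon, para to a large group, a trifluoromethyl with its 4 heavy atoms can replace hydrogen without a step that can be read beyond the scatter, which the earlier compounds could not show, since their one step altered only the other side of the selenourea. Nothing available bears on why the numbers stay together.

From the compounds shown here alone, whether an amine, a carboxylic acid or a methoxy group on this same aromatic carbon would give a step beyond the scatter remains open, and so does the effect of a chlorine elsewhere on the anilino ring. It is equally open whether a longer chain in place of propoxy in compound 1 would move the number in this assay at all, as no step shown so far has left the scatter.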